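Replacing hydroxy in compound 1 with (4-chlorophenyl)amino

This account rests on a few compounds, and the source may have more. Where it says the series, first, only, none or still open, it means among the compounds named here.

In a functional assay on NCI-H460 cells (Homo sapiens) for inhibition, read by MTT assay, with a stated time of 24 h, tested at 0.1 ug/mL (on this read-out higher numbers stand for more inhibition of growth at the one concentration tested and lower numbers for less inhibition of growth), compound 1 `CC(=O)SCCC(CCCCC(=O)O)SC(C)=O` gives 9.96%. Compound 2 `O=C(CCCCC1CCSS1)Nc1ccc(Cl)cn1` gives 3.93%, and compound 3 `O=C(CCCCC1CCSS1)Nc1ccc(Br)cn1` gives 9%. These three numbers lie within the scatter of one another, so compound 1 cannot be told apart from the other two.

The step followed here leads to compound 4 `CC(=O)SCCC(CCCCC(=O)Nc1ccc(Cl)cc1)SC(C)=O`: (4-chlorophenyl)amino in place of hydroxy on a carbonyl carbon. In words, (4-chlorophenyl)amino stands in place of hydroxy on a carbonyl carbon. For the measured compounds named here, no measured pair makes this change directly. Going by the values given here, the only measured step, a number 5.1 percentage points higher from compound 2 to compound 3 (within the scatter), is bromo in place of chloro on an aromatic carbon, and it stays within the scatter. It therefore says little about replacing hydroxy and offers only indirect guidance. Compound 2 also carries a chlorine-bearing aromatic ring on an amide, and its value of 3.93% gives no sign that such a group raises the number. A step beyond the scatter is therefore not expected in this assay, and no direction is firmly expected, although the data cannot exclude a larger change. For compound 4 the expected value is 12%, with an estimated range from 3% to 30%. This estimate means an expected a number 2 percentage points higher from compound 1 to compound 4 (within the scatter).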

Compound 4, percent growth inhibition at one concentration: 9.89%
Estimate against measurement, compound 4: 2.1 percentage points above; the range from low to high includes it.
By their numbers in this assay, from the lowest: compounds 2, 3, 4 and 1 (each within the scatter of the next).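

For the compounds shown here, this is the first direct look at the carbonyl carbon of compound 1, and in this assay the exchange of hydroxy for (4-chlorophenyl)amino gives a number 0.1 percentage points lower from compound 1 to compound 4 (within the scatter). Going by these compounds alone, the earlier compounds could only hint at this, since their one measured step concerned a halogen on an aromatic carbon, whereas here the carboxylic acid of compound 1 becomes an amide carrying a six-membered aromatic ring, and the read-out at this single concentration does not separate the two compounds. No separate measurement is at hand that would help to interpret this result.

The compounds shown leave open whether any other group on this carbonyl carbon, such as benzylamino, morpholine or a methyl ester, would give a step beyond the scatter. They also leave open whether bromo in place of the chloro on the phenyl ring of compound 4, or a second chloro on that ring, would separate from compound 4 in this read-out.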